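This account rests on a few compounds, and the source may have more. Where it says the series, first, only, none or still open, it means among the compounds named here.

Of the compounds shown here, two with a shared core have been measured in an assay on CHO cells for binding affinity to metabotropic glutamate receptor 2 (Rattus norvegicus); on this read-out higher numbers stand for weaker inhibition and lower numbers for stronger inhibition. Compound 1 `N[C@]1(C(=O)O)[C@H]2[C@@H](C[C@H]1OCc1ccccc1)[C@]2(F)C(=O)O` gives 7.14 nM in this assay. Compound 2 `N[C@]1(C(=O)O)[C@H]2[C@@H](C[C@H]1OCc1cc(F)ccc1F)[C@]2(F)C(=O)O`, which carries a 2,5-difluorophenyl in place of phenyl on a saturated chain carbon bound to an oxygen on a saturated carbon, gives 14.4 nM in this assay. Compound 2 has the higher of the two numbers, but the step of a 2.0-fold higher number from compound 1 to compound 2 (0.30 log units; within the scatter) stays inside the usual scatter, so the two values cannot be told apart with confidence.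

Compound 3 `N[C@]1(C(=O)O)[C@H]2[C@@H](C[C@H]1OCc1ccc(Cl)cc1Cl)[C@]2(F)C(=O)O` is not yet measured. It differs from compound 2 in one place: 2,4-dichlorophenyl in place of 2,5-difluorophenyl on a saturated chain carbon bound to an oxygen on a saturated carbon. Within the data shown here, the only measured step that bears on this change is the one from compound 1 to compound 2, where a swap of the group in this same place, phenyl for 2,5-difluorophenyl, moved the number by a 2.0-fold higher number from compound 1 to compound 2 (0.30 log units; within the scatter), within the scatter. On that basis only a small step is expected, a 1.3-fold higher number from compound 2 to compound 3 (0.10 log units; within the scatter), with no clear direction beyond the scatter. Compound 3 is therefore estimated at 18 nM in this assay, with a range from 6 nM to 55 nM.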

Compound 3, inhibition constant: 3.89 nM
The estimate for compound 3 lay 4.6-fold (0.67 log units) above the measured number; measured number below the stated range.
By their numbers in this assay, from the lowest: compounds 3, 1 and 2 (each within the scatter of the next, the first and the last beyond it).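

This position on the shared core does respond to the group placed there in this assay: 2,4-dichlorophenyl in place of 2,5-difluorophenyl gives a 3.7-fold lower number from compound 2 to compound 3 (0.57 log units; beyond the scatter), the only step among these compounds that clears the scatter. Set against the plain phenyl of compound 1, the same group gives a 1.8-fold lower number from compound 1 to compound 3 (0.26 log units; within the scatter), so neither halogen-bearing ring can be told apart from plain phenyl, and only the two halogen-bearing rings can be told apart from each other. No measurement at hand says why these two rings differ.

The step from compound 2 to compound 3 swaps fluorine for chlorine and also changes where the halogens sit on the ring, so these compounds cannot say which of the two changes matters; 2,5-dichlorophenyl and 2,4-difluorophenyl would separate them. As far as these compounds go, it also remains open how far the position tolerates other shapes, such as a cyclohexyl ring in place of the phenyl or a longer chain carrying the phenyl.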